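Oxime-ether piperazines: aryl swap on the ring nitrogen

The compounds below may be only part of what the source reports. "The series", "measured", "known", "first", "only" and "open" are said of these compounds alone.

Compound 3 `CCO/N=C(\CCN1CCN(c2ccccc2)CC1)c1ccccc1` is measured in a functional assay on HEK293 cells with D(4) dopamine receptor (Homo sapiens) as the target, read by FLIPR (a higher number here means that more compound is needed for the effect, a lower number that less compound is needed), where compound 3 gives 109 nM. For the measured compounds named here, this is the highest of the three numbers so far. Compound 1 `Cc1ccccc1/C(CCN1CCN(c2ccccn2)CC1)=N\O` gives 20.3 nM in this assay, and compound 2 `O/N=C(\CCN1CCN(c2ccccn2)CC1)c1ccc(F)cc1F` gives 8.9 nM in this assay; both of these numbers lie well below that of compound 3, the gap to compound 1 and the larger gap to compound 2 each being beyond the scatter. Compounds 1 and 2 differ from compound 3 in more than one place, so no single change can be read from those gaps.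

Compound 4 `CCO/N=C(\CCN1CCN(c2ncccc2C)CC1)c1ccccc1` is not yet measured. It differs from compound 3 by 3-methylpyridin-2-yl in place of phenyl on an amine nitrogen in a ring. Going by the values given here, no step between two measured compounds matches this change. Given that compounds 1 and 2, with a six-membered aromatic ring containing one hetero atom on the ring nitrogen, give the lower numbers in this assay, compound 4 is expected to give a lower number than compound 3, by a modest step that may or may not exceed the scatter. The estimate for compound 4 in this assay is 50 nM, with a range from 15 nM to 200 nM, which means an expected step of a 2.2-fold lower number from compound 3 to compound 4 (0.34 log units; beyond the scatter).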

Compound 4, half-maximal effective concentration: 253 nM
The estimate for compound 4 lay 5.1-fold (0.70 log units) below the measured number, and the stated range ends below it.
By their numbers in this assay, from the lowest: compound 2; then compound 1; then compound 3; then compound 4.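

For the compounds shown here, with the core of compound 3 held fixed, the first step at this position is a higher number in this assay: 3-methylpyridin-2-yl in place of phenyl on the amine nitrogen in the ring gives a 2.3-fold higher number from compound 3 to compound 4 (0.37 log units; beyond the scatter), a modest step. A six-membered aromatic ring with one hetero atom on this nitrogen therefore does not bring a lower number on this core, so the low numbers of compound 1 and compound 2, which differ from compound 3 in more than one place, cannot be credited to that kind of ring alone. No measurement shown here bears on the reason for this rise, and the swap adds a ring nitrogen and a methyl group together, so its effect stays undivided.

On these data alone, whether the rise follows the methyl group, the ring nitrogen or only their combination remains open, and unsubstituted pyridin-2-yl or a methylphenyl group on the same core would separate these. As far as these compounds go, how a pyrimidin-2-yl group at this position would read, and whether this step carries over to the free oxime of compound 1 and compound 2, also remains open.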